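Removing a Methoxy Group from an Aryloxy-Substituted Bicyclic Core

The source may hold more compounds than are shown below. What is called first, only, known or untested is meant among the compounds shown, and "the series" means these compounds.

Compound 1 `COc1ccc2ncnc(Oc3ccc(F)cc3F)c2c1`: > 32000 nM
Compound 2 `Fc1ccc(Oc2ncnc3ccccc23)c(F)c1`: > 32000 nM
Compound 3 `COc1cc2ccnc(Oc3ccc(F)cc3F)c2cc1OC`: 630 nM

In an assay on HEK293-TREx cells for antagonist activity at transient receptor potential cation channel subfamily A member 1 (Homo sapiens), read by fluorescence and calcium flux, with a stated time of 72 h (on this read-out lower numbers stand for stronger inhibition and higher numbers for weaker inhibition), compound 1 reaches only the limit > 32000 nM and no number. Compound 2 likewise gives only the limit > 32000 nM. The step that the two limits leave unreadable from compound 1 to compound 2 is therefore unreadable, because of the limit of > 32000 nM in this assay, at which 2 of the 3 values shown sit. The change itself is hydrogen in place of methoxy on an aromatic carbon. For the measured compounds named here, compound 3 is the one compound with a number, 630 nM in this assay; the difference between the cores of compound 1 and compound 3 is not broken down here.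

Compound 4 `COc1ccc2c(Oc3ccc(F)cc3F)nccc2c1` carries the same kind of change, (hydrogen in place of methoxy on an aromatic carbon), here with the place being ortho to a methoxy group, which the first place lacks. With the earlier step unreadable, a moderate loss is expected, a 4.0-fold higher number from compound 3 to compound 4 (0.60 log units; beyond the scatter). Compound 4 is thus estimated at 2500 nM, between 600 nM and 15000 nM.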

Compound 4, half-maximal inhibitory concentration: 1300 nM
The estimate for compound 4 lay 1.9-fold (0.28 log units) above the measured number; measured number inside the range.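

In this assay, hydrogen in place of methoxy on an aromatic carbon gives a 2.1-fold higher number from compound 3 to compound 4 (0.31 log units; beyond the scatter), so on this core the change weakens inhibition only modestly. The same change on the core of compound 1 offers no size to set beside it, since compound 1 and compound 2 give limits and not numbers: the limit of > 32000 nM in this assay, at which 2 of the 4 values shown sit. The series therefore shows the size of this change on one core only, and it does not show whether that size carries over from one core to the other.

The compounds shown leave open how an amine, a carboxylic acid or a longer chain would fare in place of the methoxy group. They also leave open whether the remaining methoxy group of compound 4 could be replaced by hydrogen as well.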